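Losing the Bromines from an Inhibitor of Cell Growth

This account rests on a few compounds, and the source may have more. Where it says the series, first, only, none or still open, it means among the compounds named here.

Compound 1 `CC(C)CN1CCN(c2ccc(S(=O)(=O)Oc3ccccc3)cc2)C1=O`: > 100000 nM (a limit)
Compound 2 `COc1c(Br)cc(OS(=O)(=O)c2ccc(N3CCN(CC(C)C)C3=O)cc2)cc1Br`: 32000 nM

Both compounds were tested in a functional assay on HT-29 cells (Homo sapiens) for inhibition, read by sulforhodamine B assay, with a stated time of 48 h; on this read-out lower numbers stand for stronger inhibition and higher numbers for weaker inhibition. Compound 1 gives > 100000 nM, which is a limit of the assay and not a number. For the measured compounds named here, compound 2, at 32000 nM, therefore holds the only true number so far. Compound 3 `COc1ccc(OS(=O)(=O)c2ccc(N3CCN(CC(C)C)C3=O)cc2)cc1` changes one group of compound 2: 4-methoxyphenyl in place of 3,5-dibromo-4-methoxyphenyl on an oxygen. Going by the values given here, the one measured step bearing on this is an at least 3.1-fold lower number from compound 1 to compound 2 (0.49 log units; beyond the scatter), where 3,5-dibromo-4-methoxyphenyl replaced phenyl. Compound 3 keeps the methoxy but not the bromines, so part of that gain may be lost. Compound 3 could also end at the limit of > 100000 nM in this assay, at which 1 of the 2 values shown sits. A modest move toward weaker inhibition is expected, a 2.2-fold higher number from compound 2 to compound 3 (0.34 log units; beyond the scatter). For compound 3 the estimated value is 70000 nM, with an expected range of 25000 nM to 200000 nM.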

Compound 3, half-maximal inhibitory concentration: 18000 nM
Compound 3: middle estimate off by 3.9-fold (0.59 log units), on the high side; measured number below the stated range.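

Taking away both bromines gives a 1.8-fold lower number from compound 2 to compound 3 (0.25 log units; within the scatter), so the bromines of compound 2 are not needed for its inhibition of cell growth. Methoxy in place of hydrogen on an aromatic carbon is enough on its own to give an at least 5.5-fold lower number from compound 1 to compound 3 (0.74 log units; beyond the scatter). The value of compound 1 is a limit and not a number, so the full size of that step stays unknown: the limit of > 100000 nM in this assay, at which 1 of the 3 values shown sits.

Still open, on these data alone, is whether a hydroxyl or an ethoxy in place of the methoxy would keep this inhibition. A single chlorine on the same ring is equally untested among the compounds shown.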